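This account rests on a few compounds, and the source may have more. Where it says the series, first, only, none or still open, it means among the compounds named here.

Compound 1 `COc1ccc(-c2cn(Cc3ccc(F)cc3)c(=O)c(C(=O)NC3CCCCCC3)c2C)cc1` in an assay on HEK293 cells for inhibition of Lysophosphatidylserine lipase ABHD12 (Homo sapiens), with stated times of 30 min and 5 min (a lower number here means a stronger inhibitor, a higher number a weaker inhibitor), gives > 10000 nM, which is a limit of the assay and not a number.
Compound 2 `O=C(NC1CCCCCC1)c1c(-c2ccccc2)c(Br)cn(Cc2ccc(F)cc2)c1=O` in this assay gives > 10000 nM, again a limit of the assay.
Compound 3 `COc1ccc(-c2c(Br)cn(Cc3ccc(F)cc3)c(=O)c2C(=O)NC2CCCCCC2)cc1` in this assay gives > 10000 nM, also a limit of the assay.

The compound still to be measured is compound 4 `Cc1c(-c2ccccc2)cn(Cc2ccc(F)cc2)c(=O)c1C(=O)NC1CCCCCC1`. It differs from compound 1 by one change: hydrogen in place of methoxy on an aromatic carbon. The same change is made between two measured compounds, from compound 3 to compound 2: hydrogen in place of methoxy on an aromatic carbon. The place lines of the two changes read word for word the same, so it is the same change in both pairs. What it did in this assay is a step that the two limits leave unreadable from compound 3 to compound 2; two limits leave its size unreadable. Compound 1 and compound 3 differ in more than one place, and the difference between the two cores is not broken down here. What the three measurements share is this: the limit of > 10000 nM in this assay, at which 3 of the 3 values shown sit.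

On that evidence, compound 4 is expected to sit at the limit as well, since every compound shown, including compound 1 with > 10000 nM, returns only a limit in this assay. The step from compound 1 to compound 4 in this assay is expected to be a step that the limit leaves unreadable from compound 1 to compound 4, an expectation that rests solely on the limit of > 10000 nM in this assay, at which 3 of the 3 values shown sit, and on a step that the two limits leave unreadable from compound 3 to compound 2. For compound 4 the estimated value in this assay is 20000 nM, with a range from 8000 nM to 60000 nM.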

Compound 4, half-maximal inhibitory concentration: 2500 nM
The estimate for compound 4 lay 8.0-fold (0.90 log units) above the measured number, outside the stated range (below it).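

In this assay, the change from 4-methoxyphenyl to phenyl on the core of compound 1 gives an at least 4.0-fold lower number from compound 1 to compound 4 (0.60 log units; beyond the scatter), so on this core the compound without the methoxy is the stronger inhibitor, and the size printed is a minimum, not an exact figure. This does not show that the change carries from one core to another: the same change on the core of compound 3, leading to compound 2, cannot be read as both values are limits of the assay, and compound 2 carries phenyl yet yields no measured number, so it goes against any rule that phenyl alone is enough. The transfer therefore rests on a single readable pair, with most of the compounds shown still sitting at the limit: the limit of > 10000 nM in this assay, at which 3 of the 4 values shown sit.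

The compounds shown hold only methoxy or hydrogen at this place on the aromatic ring, so it stays open how a hydroxyl, a chlorine or an amine there would read in this assay. As far as these compounds go, it also stays open whether the step seen on the core of compound 1 would appear on any other core that gives a measured number rather than a limit.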